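This account rests on a few compounds, and the source may have more. Where it says the series, first, only, none or still open, it means among the compounds named here.

Working notes on the series.

Compound 1, `NC(=O)N1CCN(C(=S)SCc2cn(Cc3ccccc3F)nn2)CC1`, gives 11300 nM in a functional assay on MGC-803 cells (Homo sapiens) for cytotoxicity, read by MTT assay, with a stated time of 72 h; on this read-out higher numbers stand for weaker inhibition and lower numbers for stronger inhibition. Compound 2, `CCNC(=O)N1CCN(C(=S)SCc2cn(Cc3ccccc3F)nn2)CC1`, gives 2830 nM in this assay. The move a 4.0-fold lower number from compound 1 to compound 2 (0.60 log units; beyond the scatter) rests on one change, (ethyl in place of hydrogen on an amide-type nitrogen).

Compound 3, `COc1cc(Cn2cc(CSC(=S)N3CCN(C(N)=O)CC3)nn2)cc(OC)c1OC`, has a different core; the difference between its core and the core of compound 1 is not broken down here. For compound 3 this assay reports only a limit, > 128000 nM, and not a number. This is the limit of > 128000 nM in this assay, at which 1 of the 3 values shown sits.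

Compound 4, `CCNC(=O)N1CCN(C(=S)SCc2cn(Cc3cc(OC)c(OC)c(OC)c3)nn2)CC1`, is not yet measured in this assay. It differs from compound 3 by ethyl in place of hydrogen on an amide-type nitrogen, the same change, at the same kind of place, as from compound 1 to compound 2.

The step from compound 3 to compound 4 is expected to be of the order of the step from compound 1 to compound 2, so an at least 2.0-fold lower number from compound 3 to compound 4 (0.30 log units; that floor lies within the scatter) is the working estimate. Because compound 3 sits at the limit of > 128000 nM in this assay, at which 1 of the 3 values shown sits, the starting point is uncertain, and compound 4 may itself return only a limit. Compound 4 is expected to give about 64000 nM in this assay. For compound 4 the expected range runs from 20000 nM to 200000 nM.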

Compound 4, half-maximal inhibitory concentration: 101000 nM
Compound 4: the middle estimate sits 1.6-fold (0.20 log units) below what was measured; the range from low to high includes it.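

Carried to the core of compound 3, ethyl in place of hydrogen on an amide-type nitrogen gives in this assay an at least 1.2-fold lower number from compound 3 to compound 4 (0.10 log units; that floor lies within the scatter), a step that can be read only as a floor. Compound 3 has only a limit, > 128000 nM, and not a number. The result is compatible with the change carrying over to this core, but it shows neither that the step here lies beyond the scatter nor that its size matches the earlier one: the same change on two cores in this assay, a 4.0-fold lower number (0.60 log units; beyond the scatter) from compound 1 to compound 2 and an at least 1.2-fold lower number (0.10 log units; that floor lies within the scatter) from compound 3 to compound 4; the limit leaves it open whether they differ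

The compounds shown carry only hydrogen and ethyl on this nitrogen, so it remains open on either core how a longer chain such as butyl, or an aromatic group such as phenyl, would read out. Also open, as far as these compounds go, are the true size of the step on the core of compound 3, which would need a number in place of the limit, and the behaviour of the change on any further core.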